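The compounds below may be only part of what the source reports. "The series", "measured", "known", "first", "only" and "open" are said of these compounds alone.

Compound 1, `O=C(NCCCCN1CCCCC1)Nc1ccc(-c2ccc(F)cc2)cc1`: in a functional assay on HEK293 cells for agonist activity at 5-hydroxytryptamine receptor 3A (Homo sapiens), read by FLIPR (on this read-out lower numbers stand for stronger inhibition and higher numbers for weaker inhibition), compound 1 gives 5800 nM.
Compound 2, `O=C(NCCCCN1CCCCC1)Nc1ccc(-c2ccc(F)nc2)cc1`: in this assay compound 2 gives > 30000 nM, which is a limit of the assay, not a number.
Compound 3, `O=C(NCCCCN1CCCCC1)Nc1ccc(-c2ccccn2)cc1`: in this assay compound 3 gives > 30000 nM, again a limit of the assay.

Compound 3 thus sits at the limit of > 30000 nM in this assay, at which 2 of the 3 values shown sit, together with compound 2. Compound 4, `COc1ccccc1-c1ccc(NC(=O)NCCCCN2CCCCC2)cc1`, differs from compound 3 by 2-methoxyphenyl in place of pyridin-2-yl on an aromatic carbon. The measured step that bears on this is an at least 5.1-fold higher number from compound 1 to compound 3 (0.71 log units; beyond the scatter), where a carbon-only ring was replaced by a nitrogen-containing one; the step of an at least 5.1-fold higher number from compound 1 to compound 2 (0.71 log units; beyond the scatter) points the same way. Going back to a carbon-only ring is therefore expected to give a lower number, estimated as an at least 3.7-fold lower number from compound 3 to compound 4 (0.57 log units; beyond the scatter). For compound 4 the estimate in this assay is 8000 nM, with a range from 2500 nM to 30000 nM.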

Compound 4, half-maximal inhibitory concentration in the 5-hydroxytryptamine receptor 3A assay: 7800 nM
Beside the measured number, compound 4's estimate is 1.0-fold (0.01 log units) above it, within the range that was stated.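

In the 5-hydroxytryptamine receptor 3A assay, swapping a nitrogen-containing ring for 2-methoxyphenyl brings a measurable number back, with an at least 3.8-fold lower number from compound 3 to compound 4 (0.58 log units; beyond the scatter) and an at least 3.8-fold lower number from compound 2 to compound 4 (0.58 log units; beyond the scatter). Two different carbon-only rings also read alike in the 5-hydroxytryptamine receptor 3A assay, with a 1.3-fold higher number from compound 1 to compound 4 (0.13 log units; within the scatter), so this place tolerates a change in both the group on the ring and where it sits. In the 5-hydroxytryptamine receptor 3A assay compound 2 still gives > 30000 nM, which is a limit of the assay and not a number. In the 5-hydroxytryptamine receptor 3A assay compound 3 still gives > 30000 nM, which is also a limit of the assay and not a number. Compound 2 and compound 3 thus stand together: the limit of > 30000 nM in the 5-hydroxytryptamine receptor 3A assay, at which 2 of the 4 values shown sit. In a physicochemical assay for solubility, at pH 7.4 (a higher number here means a more soluble compound, a lower number a less soluble compound), compound 3 gives 153000 nM. In the physicochemical assay compound 4 gives 114000 nM. The step between them in the physicochemical assay is a 1.3-fold lower number from compound 3 to compound 4 (0.13 log units; within the scatter).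

The compounds shown leave open whether the carbon-only ring or the methoxy group carries this recovery. An unsubstituted phenyl group would separate the two, and a nitrile on the ring would test a different group.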